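A Bromo Substituent and Growth Inhibition of Cancer Cells

The source may report more compounds than this note shows. Statements on the series, on what has been measured and on what is new or still open speak of the compounds shown alone.

Compound 1 `Cn1cc(C2CCN=C(N)N2)c2ccccc21` and compound 2 `Cn1cc(C2CCN=C(N)N2)c2cc(Br)ccc21` share one core and differ in a single place: bromo in place of hydrogen on an aromatic carbon. In a functional assay on HT-29 cells (Homo sapiens) for cytotoxicity, read by sulforhodamine B assay, with a stated time of 72 h (on this read-out higher numbers stand for weaker inhibition of growth and lower numbers for stronger inhibition of growth), compound 1 gives 4290 nM, while compound 2 gives 13700 nM, so the change produced a 3.2-fold higher number from compound 1 to compound 2 (0.50 log units; beyond the scatter). Compound 3 `CC(=O)/N=C1\NCCC(c2cn(C)c3ccccc23)N1` rests on a different core; the difference between the two cores is not broken down here. In this assay compound 3 gives 7400 nM, a number within the scatter of both compound 1 and compound 2. Compound 4 `CC(=O)/N=C1\NCCC(c2cn(C)c3cc(Br)ccc23)N1` has not yet been measured. It differs from compound 3 by bromo in place of hydrogen on an aromatic carbon, the same change that separates compound 1 from compound 2, made twice in all among the compounds shown. Compound 4 is expected to give about 19000 nM in this assay, likely between 8000 nM and 50000 nM. Among the compounds with values here, this estimate means a step of a 2.6-fold higher number from compound 3 to compound 4 (0.41 log units; beyond the scatter), kept a little smaller than the measured precedent because only one prior instance, a 3.2-fold higher number from compound 1 to compound 2 (0.50 log units; beyond the scatter), supports carrying the change onto a different core.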

Compound 4, concentration for 50% growth inhibition: 4300 nM
Compound 4: the middle estimate sits 4.4-fold (0.65 log units) above what was measured; measured number below the stated range.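

On the core of compound 3, bromo in place of hydrogen on an aromatic carbon gives, in this assay, a 1.7-fold lower number from compound 3 to compound 4 (0.24 log units; within the scatter), a step within the scatter, so this pair shows no measurable effect of the change. The change therefore did not carry over from the core of compound 1 to the core of compound 3 with the same outcome: the same change on two cores in this assay, a 3.2-fold higher number (0.50 log units; beyond the scatter) from compound 1 to compound 2 and a 1.7-fold lower number (0.24 log units; within the scatter) from compound 3 to compound 4, 5.5-fold (0.74 log units) apart, beyond the scatter of two such steps This shows that, for these two pairs, the result of adding bromo depends on the core it is placed on, but it does not show which feature of the cores is responsible, and two pairs cannot show how the change would behave on any further core.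

The compounds shown leave open whether chloro, fluoro or methoxy in that same place would also give different results on the two cores. They also leave open whether an amine or a carboxylic acid there would do so.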